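The source may hold more compounds than are shown below. What is called first, only, known or untested is meant among the compounds shown, and "the series" means these compounds.

Three compounds that share one core and differ only in the group on an aromatic nitrogen have so far been measured in an ADME assay on Caco-2 cells (Homo sapiens) for permeability (on this read-out higher numbers stand for higher permeability and lower numbers for lower permeability), on this scale. Compound 1 `CNc1cc(Nc2cccn(-c3ccccn3)c2=O)nn2c(C(=O)NC3CC3)cnc12` gives 169 nm/s and sits at the top of this small set, level with compound 3 `CNc1cc(Nc2cccn(-c3cc(C)n(C)n3)c2=O)nn2c(C(=O)NC3CC3)cnc12` at 142 nm/s once the scatter is allowed for. Their gap reads as a 1.2-fold lower number from compound 1 to compound 3 (0.08 log units; within the scatter) and carries no weight. Compound 2 `CNc1cc(Nc2cccn(-c3ccncc3)c2=O)nn2c(C(=O)NC3CC3)cnc12` stands apart at 38 nm/s and the drop reads as a 4.4-fold lower number from compound 1 to compound 2 (0.65 log units; beyond the scatter) in the data, while the way back up reads as a 3.7-fold higher number from compound 2 to compound 3 (0.57 log units; beyond the scatter) in the data.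

Compound 4 `CNc1cc(Nc2cccn(-c3ccc(F)nc3)c2=O)nn2c(C(=O)NC3CC3)cnc12` is still unmeasured. For the measured compounds named here, its one change from compound 1 is 6-fluoropyridin-3-yl in place of pyridin-2-yl on an aromatic nitrogen and no measured compound carries this new group, so the guidance is loose. Swaps at this place left compound 3 at 142 nm/s but took compound 2 down to 38 nm/s so a small fall is expected, with a wide margin. The expected size is a 1.4-fold lower number from compound 1 to compound 4 (0.15 log units; within the scatter) and this stays within the scatter. For compound 4 the estimated value is 120 nm/s with an expected range of 50 nm/s to 280 nm/s when it is measured.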

Compound 4, apparent permeability: 51 nm/s
For compound 4 the middle estimate is 2.4-fold (0.37 log units) above the measured one; low and high end bracket the measured number.
By their numbers in this assay, from the lowest: compounds 2 and 4 (each within the scatter of the next); then compounds 3 and 1 (each within the scatter of the next).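

In this assay, the 6-fluoropyridin-3-yl group places compound 4 with the low compound rather than the high pair: the data show a 3.3-fold lower number from compound 1 to compound 4 (0.52 log units; beyond the scatter) and a 2.8-fold lower number from compound 3 to compound 4 (0.44 log units; beyond the scatter), while a 1.3-fold higher number from compound 2 to compound 4 (0.13 log units; within the scatter). For the compounds shown here, compound 2 is therefore no longer the only clear fall from compound 1 at this place, yet compound 1 itself carries a six-membered aromatic ring with 1 hetero atom, so having such a ring on the nitrogen does not by itself give a low number. No available measurement bears on why the number falls with this change.

A plain pyridin-3-yl group would separate the effect of the fluorine from the rest of the change, and the compounds shown leave that split open. They also leave open how a ring carrying an amine or a carboxylic acid would read at this place.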